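Swapping Chloro for Methyl on an Aromatic Carbon

The source may hold more compounds than are shown below. What is called first, only, known or untested is meant among the compounds shown, and "the series" means these compounds.

Of the compounds shown here, three sharing one core have been measured so far. In a physicochemical assay for lipophilicity, read by HPLC, in phosphate buffer, measured as octanol-water partition, with stated times of 30 min and 48 h, at pH 7.4 (on this read-out higher numbers stand for higher lipophilicity and lower numbers for lower lipophilicity), compound 1 `CCCC(CCC)C(=O)N(C)/N=N/c1ccc(C(C)=O)cc1` gives 4.56, compound 2 `CCCC(CCC)C(=O)N(C)/N=N/c1ccc(C(=O)OC)cc1` gives 4.7 and compound 3 `CCCC(CCC)C(=O)N(C)/N=N/c1ccc(Cl)cc1` gives 4.62. Compound 3 therefore stands within the scatter of both the others, and the three cannot be ranked on these numbers.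

Compound 4 `CCCC(CCC)C(=O)N(C)/N=N/c1ccc(C)cc1` differs from compound 3 as follows: methyl in place of chloro on an aromatic carbon. This is methyl in place of chloro on an aromatic carbon, para to a large group.

For the measured compounds named here, no measured step makes this exact swap, so the closest evidence comes from changes to the group at that carbon. These are a number 0.06 log units higher from compound 1 to compound 3 (within the scatter) and a number 0.08 log units lower from compound 2 to compound 3 (within the scatter). The change within the carbonyl group, a number 0.14 log units higher from compound 1 to compound 2 (within the scatter), is also small. With only these steps as a guide, no change beyond the scatter is expected in this assay, and the estimated step is a number 0.07 log units lower from compound 3 to compound 4 (within the scatter).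

For compound 4, the estimated value is 4.55, with an expected range from 4.25 to 4.85.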

Compound 4, distribution coefficient: 4.98
Estimate against measurement, compound 4: 0.43 log units below; the measured number lies above the stated range.
By their numbers in this assay, from the lowest: compounds 1, 3, 2 and 4 (each within the scatter of the next, the first and the last beyond it).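

In this assay, this aromatic carbon proves sensitive to the group it carries: methyl in place of chloro gives a step beyond the scatter (a number 0.36 log units higher from compound 3 to compound 4 (beyond the scatter)), and methyl in place of acetyl does the same (a number 0.42 log units higher from compound 1 to compound 4 (beyond the scatter)), whereas no earlier change at this carbon went beyond the scatter. Methyl in place of methoxycarbonyl stays within it (a number 0.28 log units higher from compound 2 to compound 4 (within the scatter)), so methyl stands apart from chloro and acetyl but not from methoxycarbonyl. Even a swap of one heavy atom for another can therefore matter here, though nothing available explains this result.

Open, from the compounds shown here alone, is where an amine, a carboxylic acid or a longer chain at this carbon would fall. Also open, going by these compounds, is whether the swap of chloro for methyl gives a similar step on a different core.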